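Aryl ester variation at a saturated-carbon oxygen

The compounds below may be only part of what the source reports. "The series", "measured", "known", "first", "only" and "open" are said of these compounds alone.

Of the compounds shown here, three sharing one core have been measured in a functional assay on MDA-MB-231 cells (Homo sapiens) for antiproliferative activity, read by MTT assay, with a stated time of 72 h; a higher number here means a weaker inhibitor, a lower number a stronger inhibitor. Compound 1 `CC1=CC[C@H]2[C@H](CC[C@]2(C)O)C(C)(C)[C@@H]1CC[C@H]1[C@]2(C)CC[C@H](OC(=O)c3ccc(C)cc3)C(C)(C)O[C@H]2CC[C@@]1(C)O` gives 33400 nM. Compound 2 `CC1=CC[C@H]2[C@H](CC[C@]2(C)O)C(C)(C)[C@@H]1CC[C@H]1[C@]2(C)CC[C@H](OCc3ccccc3)C(C)(C)O[C@H]2CC[C@@]1(C)O` gives 29100 nM. Compound 3 `COc1ccc(C(=O)O[C@H]2CC[C@]3(C)[C@H](CC[C@@](C)(O)[C@H]3CC[C@@H]3C(C)=CC[C@H]4[C@H](CC[C@]4(C)O)C3(C)C)OC2(C)C)cc1` gives 30600 nM, the second highest of the three numbers, with compound 2 nearest and compound 1 furthest, both gaps within the scatter. The steps among them are small: a 1.1-fold lower number from compound 1 to compound 2 (0.06 log units; within the scatter), a 1.1-fold lower number from compound 1 to compound 3 (0.04 log units; within the scatter) and a 1.1-fold higher number from compound 2 to compound 3 (0.02 log units; within the scatter), every one within the scatter.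

Compound 4 `CC1=CC[C@H]2[C@H](CC[C@]2(C)O)C(C)(C)[C@@H]1CC[C@H]1[C@]2(C)CC[C@H](OC(=O)c3ccccc3C(F)(F)F)C(C)(C)O[C@H]2CC[C@@]1(C)O` is not yet measured. Its change from compound 3 is 2-(trifluoromethyl)phenyl in place of 4-methoxyphenyl on a carbonyl carbon. For the measured compounds named here, the steps that bear on it are the exchange of the aryl carbonyl against benzyl at the same oxygen and the exchange on the aromatic ring, and neither moved this assay beyond the scatter. He therefore expects no step beyond the scatter, and his estimate for compound 4 is 30000 nM, between 15000 nM and 60000 nM, a step of a 1.0-fold lower number from compound 3 to compound 4 (0.01 log units; within the scatter).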

Compound 4, half-maximal inhibitory concentration: 31500 nM
Beside the measured number, compound 4's estimate is 1.1-fold (0.02 log units) below it; measured number inside the range.
By their numbers in this assay, from the lowest: compounds 2, 3, 4 and 1 (each within the scatter of the next).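

In this assay, the change from 4-methoxyphenyl to 2-(trifluoromethyl)phenyl on a carbonyl carbon gives a 1.0-fold higher number from compound 3 to compound 4 (0.01 log units; within the scatter), so the aryl exchange at this position now extends beyond the 4-substituted rings of the earlier esters without leaving the scatter. The change from 4-methylphenyl gives the same reading, a 1.1-fold lower number from compound 1 to compound 4 (0.03 log units; within the scatter), and the exchange of benzyl for (2-(trifluoromethyl)phenyl)carbonyl at the oxygen, a 1.1-fold higher number from compound 2 to compound 4 (0.03 log units; within the scatter), also stays within the scatter. No measured evidence bears on why this position tolerates these exchanges.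

All four compounds carry an aromatic ring at this oxygen, so the shown data leave open what an amine, a carboxylic acid or a longer alkyl chain there would do. They also leave open whether any change to the shared core itself would move the number.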